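This account rests on a few compounds, and the source may have more. Where it says the series, first, only, none or still open, it means among the compounds named here.

Compound 1 `Cc1cccc(CN2CCc3ncn(COCc4ccccc4)c3/C(=C/c3ccccc3)C2=O)c1`: 14600 nM
Compound 2 `Cc1ccccc1CN1CCc2ncn(COCc3ccccc3)c2/C(=C/c2ccccc2)C1=O`: 31300 nM

Both numbers come from a functional assay on BGC-823 cells (Homo sapiens) for inhibition, read by MTT assay, with a stated time of 72 h; on this read-out higher numbers stand for weaker inhibition and lower numbers for stronger inhibition. Of the two, compound 2 stands higher, at 31300 nM, and is therefore the weaker inhibitor. Compound 3 `O=C1/C(=C\c2ccccc2)c2c(ncn2COCc2ccccc2)CCN1Cc1ccc2ccccc2c1` has naphthalen-2-yl in place of the 2-methylphenyl of compound 2, on a saturated chain carbon bound to an amide-type nitrogen in a ring: naphthalen-2-yl in place of 2-methylphenyl on a saturated chain carbon bound to an amide-type nitrogen in a ring. Cut one bond further out, the same difference reads 2-methylbenzyl to (naphthalen-2-yl)methyl.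

Going by the values given here, only one measured step bears on this place: a 2.1-fold higher number from compound 1 to compound 2 (0.33 log units; beyond the scatter), a modest change that puts 2-methylphenyl in place of 3-methylphenyl. Among the compounds with values here, no measured compound carries naphthalen-2-yl, so this step offers only a rough guide to size and a weak one to direction. With compound 2 at the top of the two values, a modest step toward a lower number is expected in this assay, although a step the other way cannot be excluded. The estimated change is a 2.1-fold lower number from compound 2 to compound 3 (0.32 log units; beyond the scatter). For compound 3 the expected value is 15000 nM, with an estimated range of 5000 nM to 40000 nM.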

Compound 3, half-maximal inhibitory concentration: 93300 nM
Estimate against measurement, compound 3: 6.2-fold (0.79 log units) below, outside the stated range (above it).
By their numbers in this assay, from the lowest: compound 1; then compound 2; then compound 3.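

In this assay, exchanging one six-membered aromatic ring for the two of naphthalen-2-yl gives a 3.0-fold higher number from compound 2 to compound 3 (0.47 log units; beyond the scatter), and measured against the 3-methylphenyl group the change gives a 6.4-fold higher number from compound 1 to compound 3 (0.81 log units; beyond the scatter). The earlier compounds shown here showed only what happens when a methyl group sits differently on a single ring; this result shows that a change in the ring system itself, on the saturated chain carbon bound to an amide-type nitrogen in a ring, also moves the number upward, and compound 3 is the weakest of the three. Neither replacement of the 3-methylphenyl of compound 1 lowered the number, and no data at hand explain this rise.

The three compounds cannot show whether the lower number of compound 1 depends on its methyl group at all, and a plain phenyl, a pyridine ring or a phenyl carrying an amine or a carboxylic acid would be needed at this place to tell. From the compounds shown here alone, it also stays open whether the same order would hold in other cell lines, or with the benzyloxymethyl group of the shared core replaced by a shorter chain.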